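The source may report more compounds than this note shows. Statements on the series, on what has been measured and on what is new or still open speak of the compounds shown alone.

Compound 3 `Nc1nc(N/N=C/C2CCCC2)nc2c1ncn2[C@@H]1O[C@H](CO)[C@@H](O)[C@H]1O` gives 5.6 nM in an assay on CHO-K1 cells for displacement of a labelled ligand from adenosine receptor A1 (Homo sapiens), read by scintillation counting, with a stated time of 60 min; a higher number here means a weaker inhibitor, a lower number a stronger inhibitor. Among the three measured compounds it stands second highest; its nearest neighbour is compound 2 `Nc1nc(N/N=C/c2ccc(Br)cn2)nc2c1ncn2[C@@H]1O[C@H](CO)[C@@H](O)[C@H]1O`, which gives 4.7 nM, and the step of a 1.2-fold higher number from compound 2 to compound 3 (0.08 log units; within the scatter) lies within the scatter. The furthest is compound 1 `Nc1nc(N/N=C/c2ccc(OCc3ccc(F)cc3)cc2)nc2c1ncn2[C@@H]1O[C@H](CO)[C@@H](O)[C@H]1O`, which gives 70 nM in this assay; the two values differ beyond the scatter, with compound 1 the higher.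

Compound 4 `Nc1nc(N/N=C/c2ccc(-n3ccnc3)cc2)nc2c1ncn2[C@@H]1O[C@H](CO)[C@@H](O)[C@H]1O` differs from compound 3 in one place: 4-(1H-imidazol-1-yl)phenyl in place of cyclopentyl on a carbon with a double bond to nitrogen. Among the measured compounds shown here, no measured step shows exactly this exchange. For the measured compounds named here, the only measured step at the same place, a 1.2-fold higher number from compound 2 to compound 3 (0.08 log units; within the scatter), shows a six-membered aromatic ring and a saturated carbocycle giving numbers within the scatter of each other. Going by the values given here, compound 1, the other compound with a six-membered aromatic ring bearing a further group at that place, gives a higher number than compound 3, but no single-change step connects the two, so it indicates only that an extended aryl there can sit higher. On this basis compound 4 is expected to give a somewhat higher number than compound 3, with a 3.2-fold higher number from compound 3 to compound 4 (0.51 log units; beyond the scatter) possibly reaching beyond the scatter. The estimate for compound 4 in this assay is 18 nM, with a range from 5 nM to 70 nM.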

Compound 4, inhibition constant: > 10000 nM
Compound 4 gave a limit, no number; the forecaster's own chance of this, stated with the estimate: 3%; middle value at least 550-fold (2.74 log units) from the limit.
By their numbers in this assay, from the lowest: compounds 2 and 3 (each within the scatter of the next); then compound 1. At a limit, above all of these: compound 4.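

Compound 4 stands at a limit of the assay and gives no number: the limit of > 10000 nM in this assay, at which 1 of the 4 values shown sits. This shows that the place on the carbon with a double bond to nitrogen does not tolerate every ring-bearing group, for 4-(1H-imidazol-1-yl)phenyl in place of cyclopentyl gives an at least 1700-fold higher number from compound 3 to compound 4 (3.25 log units; beyond the scatter), and in place of 5-bromopyridin-2-yl it gives an at least 2100-fold higher number from compound 2 to compound 4 (3.32 log units; beyond the scatter), although those two earlier groups lay within the scatter of each other (a 1.2-fold higher number from compound 2 to compound 3 (0.08 log units; within the scatter)). The phenyl ring alone does not account for this loss, since 1H-imidazol-1-yl in place of (4-fluorobenzyl)oxy on an aromatic carbon, with that ring kept, gives an at least 140-fold higher number from compound 1 to compound 4 (2.15 log units; beyond the scatter), so the group on that aromatic carbon can decide between a measurable number and a limit.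

The compounds shown do not tell whether the imidazole ring as such carries this loss, or whether another group on that aromatic carbon, such as an amine, a carboxylic acid or a pyrazole ring, would fall with compound 1 or with compound 4. From the compounds shown here alone, how far the true value of compound 4 lies past its limit also stays open.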